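A few compounds are considered here, and "the series" means these few. Any claim that something is new, unique, unknown or untested is made for them only; others in the source may bear on it.

Compound 1 (`CS(=O)(=O)Cc1nc2c(Sc3ccc(Cl)cc3)cc(Cl)cn2c1[N+](=O)[O-]`) reads > 31200 nM in an ADME assay on HepG2 cells (Homo sapiens) for cytotoxicity, read by MTT assay, with a stated time of 72 h (a higher number here means that more compound is tolerated, a lower number that less compound is tolerated), which is a limit and not a number. Compound 2 (`O=[N+]([O-])c1c(CS(=O)(=O)c2ccccc2)nc2c(Nc3ccc(Cl)cc3)cc(Cl)cn12`) also gives only a limit, > 3900 nM. Compound 3 (`Cc1cc(Sc2ccc(Cl)cc2)c2nc(CS(=O)(=O)c3ccccc3)c([N+](=O)[O-])n2c1`) gives a limit too, > 62500 nM. Within the data shown here, none of the three compounds therefore has a numerical value in this assay, and no pair of them differs in only one place. Compound 4 (`O=[N+]([O-])c1cnc2c(Sc3ccc(Cl)cc3)cc(Cl)cn12`) has yet to be measured. It differs from compound 1 as follows: hydrogen in place of (methylsulfonyl)methyl on an aromatic carbon. That places hydrogen where (methylsulfonyl)methyl stood on an aromatic carbon. No step beyond the usual scatter is expected in this assay, with an at least 1.0-fold lower number from compound 1 to compound 4 (0.01 log units; that floor lies within the scatter) as the estimate. For compound 4 the expected value is 30000 nM, with an estimated range from 10000 nM to 90000 nM.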

Compound 4, half-maximal cytotoxic concentration: > 7800 nM
Compound 4 ended at the assay's limit; the forecaster's own chance of this, stated with the estimate: 55%; the middle value is on the limit's open side.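

Compound 1 and compound 4 both give only limits in this assay, so the step between them cannot be read. The compounds shown leave open the concentration at which any of the four becomes cytotoxic.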